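A few compounds are considered here, and "the series" means these few. Any claim that something is new, unique, unknown or untested is made for them only; others in the source may bear on it.

Compound 1 `CC(C)n1c(/C=C2\SC(=O)N(CC(=O)N3CCCCC3)C2=O)nc2ccccc21`: in a functional assay on DU-145 cells (Homo sapiens) for inhibition, read by MTT assay, with a stated time of 48 h (on this read-out higher numbers stand for weaker inhibition and lower numbers for stronger inhibition), compound 1 gives 42200 nM.
Compound 2 `Cn1c(/C=C2\SC(=O)N(CC(=O)N3CCCCC3)C2=O)nc2ccccc21`: in this assay compound 2 reaches only the limit > 50000 nM, which is not a number.
Compound 3 `CCn1c(/C=C2\SC(=O)N(CC(=O)Nc3cc(C(C)(C)C)on3)C2=O)nc2ccccc21`: in this assay compound 3 likewise reaches only the limit > 50000 nM.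

Among the three, compound 1 is the only one with a measured number; the other two sit at the limit of > 50000 nM in this assay, at which 2 of the 3 values shown sit. Within the data shown here, the one measured step, an at least 1.1-fold higher number from compound 1 to compound 2 (0.07 log units; that floor lies within the scatter), concerns the substituent on the aromatic nitrogen and tells little, its floor lying within the scatter. Compound 4 `CC1CN(C(=O)CN2C(=O)S/C(=C\c3nc4ccccc4n3C(C)C)C2=O)CC(C)O1` differs from compound 1 elsewhere: 2,6-dimethylmorpholin-4-yl in place of piperidin-1-yl on a carbonyl carbon. Among the measured compounds shown here, no measured pair touches this carbonyl carbon, so the account rests on compound 1 alone and on the closeness of all three values to the limit. The expected step is a 1.2-fold higher number from compound 1 to compound 4 (0.07 log units; within the scatter), nothing beyond the scatter. For compound 4 in this assay the estimate is 50000 nM, within 20000 nM to 125000 nM, with a good chance that only a limit is reported.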

Compound 4, half-maximal inhibitory concentration: > 50000 nM
Compound 4: a limit, no number; the forecaster's own chance of this, stated with the estimate: 55%; the middle value sits exactly at the limit.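

The carbonyl carbon now has its first measured change: in this assay, 2,6-dimethylmorpholin-4-yl in place of piperidin-1-yl gives an at least 1.1-fold higher number from compound 1 to compound 4 (0.07 log units; that floor lies within the scatter). Compound 4 gives a limit and not a number, so the true size of this step cannot be read, and the change brings no value clear of the limit at this position. Compound 1 remains the only compound with a measured number, and the others share one limit: the limit of > 50000 nM in this assay, at which 3 of the 4 values shown sit.

On these data alone, what a smaller ring such as pyrrolidin-1-yl or an open-chain diethylamino group would give on this carbonyl carbon remains open. So does the question of whether the ring oxygen or the two methyl groups of 2,6-dimethylmorpholin-4-yl would matter when taken apart.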